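A few compounds are considered here, and "the series" means these few. Any claim that something is new, unique, unknown or untested is made for them only; others in the source may bear on it.

Measured compounds:
- compound 1 `COc1cc2c(Oc3ccc(NC(=O)c4nn(-c5ccccc5Br)c(=O)c5ccccc45)cc3F)ccnc2cc1OCCCN1CCCC1`: 1020 nM
- compound 2 `COc1ccc(-n2nc(C(=O)Nc3ccc(Oc4ccnc5cc(OCCCN6CCCC6)c(OC)cc45)c(F)c3)c3ccccc3c2=O)cc1`: 3450 nM

In a functional assay on MDA-MB-231 cells (Homo sapiens) for cytotoxicity, read by MTT assay, with a stated time of 72 h (a higher number here means a weaker inhibitor, a lower number a stronger inhibitor), compound 1 gives 1020 nM, the lowest of the two numbers at hand. Among the compounds with values here, the only measured step, a 3.4-fold higher number from compound 1 to compound 2 (0.53 log units; beyond the scatter), concerns the group on the aromatic nitrogen and leaves the basic amine on the propyl chain untouched.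

Compound 3 `COc1cc2c(Oc3ccc(NC(=O)c4nn(-c5ccccc5Br)c(=O)c5ccccc45)cc3F)ccnc2cc1OCCCN1CCC(C)CC1` differs from compound 1 only at that amine: 4-methylpiperidin-1-yl in place of pyrrolidin-1-yl on a saturated chain carbon, three bonds along the chain from an oxygen on an aromatic ring. Within the data shown here, no measured step touches this position, so nothing speaks for a change in either direction; the carbonyl-bearing core and the bromophenyl group that set compound 1 apart from compound 2 are retained. The step from compound 1 to compound 3 is therefore expected to stay within the scatter of this assay, a 1.0-fold lower number from compound 1 to compound 3 (0.01 log units; within the scatter). For compound 3 the estimate in this assay is 1000 nM, with a range of 400 nM to 2500 nM.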

Compound 3, half-maximal inhibitory concentration: 1240 nM
Compound 3: middle estimate off by 1.2-fold (0.09 log units), on the low side; the measured number falls inside the stated range.
By their numbers in this assay, from the lowest: compounds 1 and 3 (each within the scatter of the next); then compound 2.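

In this assay, within the data shown here, the first step at this position, 4-methylpiperidin-1-yl in place of pyrrolidin-1-yl at the end of the propyl chain, lies within the scatter (a 1.2-fold higher number from compound 1 to compound 3 (0.08 log units; within the scatter)). The six-membered ring with its methyl group and the five-membered ring therefore cannot be told apart in this assay, at least on the core of compound 1 with its 2-bromophenyl group. So far, only the step on the aromatic nitrogen lies beyond the scatter (a 3.4-fold higher number from compound 1 to compound 2 (0.53 log units; beyond the scatter)), and no supporting measurement bears on either step.

As far as these compounds go, it remains open whether a morpholine ring, a dimethylamino group or a carboxylic acid in place of these rings would read the same, and whether a longer chain would. Also open, from the compounds shown here alone, is whether 4-methylpiperidin-1-yl behaves alike with 4-methoxyphenyl on the aromatic nitrogen.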